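Phenyl in place of a sulfated tail on a sulfated sugar

The source may report more compounds than this note shows. Statements on the series, on what has been measured and on what is new or still open speak of the compounds shown alone.

Measured so far:
- compound 1, `CO[C@H]1O[C@H](CNC(=O)CN(CCOS(=O)(=O)O)C(C)=O)[C@@H](OS(=O)(=O)O)[C@H](OS(=O)(=O)O)[C@@H]1OS(=O)(=O)O`: 280000 nM
- compound 2, `CCN(CC(=O)NC[C@H]1O[C@H](OC)[C@@H](OS(=O)(=O)O)[C@@H](OS(=O)(=O)O)[C@@H]1OS(=O)(=O)O)C(=O)CCCCCCCCCOS(=O)(=O)O`: 545000 nM

Going by the values given here, only two compounds have numbers in an assay on isolated protein for binding affinity to vascular endothelial growth factor A, long form (Homo sapiens), read by surface plasmon resonance; a higher number here means weaker binding, a lower number tighter binding. Compound 1 has the lower of the two, and its nearest neighbour is compound 2; the gap between them lies within the scatter, so the two cannot be told apart on these data. Both sit at very weak binding.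

Compound 3, `CO[C@H]1O[C@H](CNC(=O)CN(C(C)=O)c2ccccc2)[C@@H](OS(=O)(=O)O)[C@H](OS(=O)(=O)O)[C@@H]1OS(=O)(=O)O`, is the next compound to be measured. It differs from compound 1 in one place: phenyl in place of 2-(sulfooxy)ethyl on an amide-type nitrogen. Among the compounds with values here, no step between two measured compounds is known that would show what such a change does here, so the expectation rests on the structures alone. The group that leaves carries one of the sulfate-bearing chains of compound 1, while the phenyl that enters carries none, and the remaining change is an exchange of a short open chain for an aromatic ring.

Compound 3 is therefore expected to bind somewhat more weakly than compound 1, with the step from compound 1 to compound 3 estimated at a 1.6-fold higher number from compound 1 to compound 3 (0.21 log units; within the scatter), a shift that may not clear the scatter. The estimate for compound 3 in this assay is 450000 nM, with a range from 150000 nM to 1500000 nM.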

Compound 3, dissociation constant: 76000 nM
For compound 3 the middle estimate is 5.9-fold (0.77 log units) above the measured one; measured number below the stated range.
By their numbers in this assay, from the lowest: compound 3; then compounds 1 and 2 (each within the scatter of the next).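

In this assay, the amide-type nitrogen turns out not to depend on its sulfated chain: phenyl in place of 2-(sulfooxy)ethyl gives a 3.7-fold lower number from compound 1 to compound 3 (0.57 log units; beyond the scatter), a change that clears the scatter and goes toward tighter binding. Compound 1 and compound 2 both carried a sulfated chain and could not be told apart, so they gave no sign that a position on this nitrogen could move the number at all, and still less that an aromatic ring with no sulfate could serve there better than a chain with one. Nothing at hand accounts for the gain.

Compound 3, at 76000 nM, still binds very weakly, and its single change removes a sulfated chain and brings in an aromatic ring at once, so the compounds shown cannot say which of the two matters. Going by these compounds, how a plain ethyl group, a cyclohexyl ring, a benzyl group or a phenyl ring bearing a carboxylic acid would behave on the same nitrogen remains open.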